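The source may report more compounds than this note shows. Statements on the series, on what has been measured and on what is new or still open speak of the compounds shown alone.

Measured in a functional assay on A549 cells (Homo sapiens) for inhibition, read by sulforhodamine B assay, with a stated time of 48 h; a lower number here means a stronger inhibitor of growth, a higher number a weaker inhibitor of growth:
Compound 1 `COC(=O)[C@@]1(C)CCC=C2[C@@H]1CC[C@@H](C)[C@]2(C)Cc1c[nH]c2ccccc12`: 5000 nM
Compound 2 `COC(=O)[C@@]1(C)CCC=C2[C@@H]1CC[C@@H](C)[C@]2(C)Cc1c[nH]c2c(C)cccc12`: 11000 nM
Compound 3 `COC(=O)[C@@]1(C)CC[C@@H]2C3=C1CC[C@@H](C)[C@]3(C)C[C@@H]1c3ccccc3N[C@H]21`: 39000 nM

Compound 2 differs from compound 1 by methyl in place of hydrogen on an aromatic carbon, and this single change gave a 2.2-fold higher number from compound 1 to compound 2 (0.34 log units; beyond the scatter). Compound 3 is built from the same atoms as compound 1 joined differently; the difference between the two cores is not broken down here, and in this assay compound 3 stands highest of the three numbers.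

Compound 4 `COC(=O)[C@@]1(C)CC[C@@H]2C3=C1CC[C@@H](C)[C@]3(C)C[C@@H]1c3cccc(C)c3N[C@H]21` has not yet been measured. It differs from compound 3 by methyl in place of hydrogen on an aromatic carbon. The surroundings are not identical, since in compound 2 the ring belongs to a fused or bridged system of two rings and in compound 4 to one of five rings, so this is the same kind of change rather than the same change. A step of about a 2.1-fold higher number from compound 3 to compound 4 (0.31 log units; beyond the scatter) is expected in this assay because a 2.2-fold higher number from compound 1 to compound 2 (0.34 log units; beyond the scatter) was modest. Compound 4 is therefore estimated at 80000 nM, within 30000 nM to 200000 nM.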

Compound 4, concentration for 50% growth inhibition: 30000 nM
Beside the measured number, compound 4's estimate is 2.7-fold (0.43 log units) above it; the range from low to high includes it.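

In this assay adding the methyl to the aromatic ring of the fused system of five rings gave a 1.3-fold lower number from compound 3 to compound 4 (0.11 log units; within the scatter) and so made no difference that can be read. Set beside the earlier step, the same change did not carry over unchanged from one core to the other: the same change on two cores in this assay, a 2.2-fold higher number (0.34 log units; beyond the scatter) from compound 1 to compound 2 and a 1.3-fold lower number (0.11 log units; within the scatter) from compound 3 to compound 4, 2.9-fold (0.46 log units) apart, beyond the scatter of two such steps

For the compounds shown here, with only one pair on each core, this shows that a methyl step seen on one core cannot be assumed on the other, but not why the two cores differ. The compounds shown leave open whether a chlorine atom or a methoxy group in place of this methyl would also behave differently on the two cores.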